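The source may hold more compounds than are shown below. What is called first, only, known or untested is meant among the compounds shown, and "the series" means these compounds.

Measured so far in an assay on HEK293 cells for displacement of a labelled ligand from Melanocortin receptor 4 (Homo sapiens); a lower number here means a stronger inhibitor, a higher number a weaker inhibitor:
compound 1, `NC(COCc1ccccc1)c1cc(F)ccc1N1CCN(C(=O)CCc2ccc(Cl)cc2Cl)CC1`, gives 1000 nM.
compound 2, `NCCNC(COCc1ccccc1)c1cc(F)ccc1N1CCN(C(=O)CCc2ccc(Cl)cc2Cl)CC1`, gives 400 nM.

Within the data shown here, compound 2 stands lowest of the two numbers; the only neighbour is compound 1, and the step of a 2.5-fold lower number from compound 1 to compound 2 (0.40 log units; beyond the scatter) lies beyond the scatter. Compound 3, `NCCC(=O)NC(COCc1ccccc1)c1cc(F)ccc1N1CCN(C(=O)CCc2ccc(Cl)cc2Cl)CC1`, is not yet measured. It differs from compound 2 by (2-aminoethyl)carbonyl in place of 2-aminoethyl on an amine nitrogen. Among the measured compounds shown here, the single measured step, a 2.5-fold lower number from compound 1 to compound 2 (0.40 log units; beyond the scatter), shows that attaching the 2-aminoethyl group to that nitrogen gave a modest gain; no measured pair shows what a carbonyl inserted into that group does. The change from compound 2 to compound 3 is therefore expected to move the number only a little, most likely within the scatter, with a slight lean toward a higher number. The expected step in this assay is a 1.8-fold higher number from compound 2 to compound 3 (0.24 log units; within the scatter). The estimate for compound 3 in this assay is 700 nM, with a range from 250 nM to 2000 nM.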

Compound 3, inhibition constant: 210 nM
Compound 3: the middle estimate sits 3.3-fold (0.52 log units) above what was measured; the whole stated range lies above it.
By their numbers in this assay, from the lowest: compounds 3 and 2 (each within the scatter of the next); then compound 1.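

In this assay a carbonyl can enter the group on this amine nitrogen without a readable shift, since a 1.9-fold lower number from compound 2 to compound 3 (0.28 log units; within the scatter) leaves (2-aminoethyl)carbonyl and 2-aminoethyl indistinguishable here. Measured against hydrogen on the same nitrogen, the acylated form still shows a 4.8-fold lower number from compound 1 to compound 3 (0.68 log units; beyond the scatter) and so is the second substituent at this position to stand apart from compound 1, which means that this position accepts both an amine and an amide link. No supporting data bear on why the two groups match.

As far as these compounds go, whether the terminal amine matters stays open: an acetyl group, or a hydroxyl or carboxylic acid at the chain end, would separate its contribution from that of the carbonyl. A longer chain on the same nitrogen is also an open question.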